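Moving the chlorine: compound 1 to compound 3 in cytotoxicity

A few compounds are considered here, and "the series" means these few. Any claim that something is new, unique, unknown or untested is made for them only; others in the source may bear on it.

Compound 1 `Cn1c(-c2cccc(Cl)c2)cnc1NC(=O)c1ccc(F)cc1`: > 50000 nM
Compound 2 `Cn1c(-c2ccccc2)cnc1NC(=O)c1ccccc1`: > 100000 nM

In a toxicity assay on THP-1 cells (Homo sapiens) for inhibition (on this read-out higher numbers stand for lower toxicity in this test and lower numbers for higher toxicity in this test), compound 1 gives > 50000 nM, a limit of the test rather than a number. Compound 2 gives > 100000 nM, also a limit. Compound 1 thus stands at the limit of > 50000 nM in this assay, at which 1 of the 2 values shown sits. The other value shown sits at the limit of > 100000 nM in this assay, at which 1 of the 2 values shown sits. Compound 3 `Cn1c(-c2ccc(Cl)cc2)cnc1NC(=O)c1ccc(F)cc1` is not yet measured; it differs from compound 1 by 4-chlorophenyl in place of 3-chlorophenyl on an aromatic carbon. Among the measured compounds shown here, no step between measured compounds is known, so no change beyond the usual scatter is expected in this assay. Compound 3 is expected to give 60000 nM (range 30000 nM to 150000 nM), an expected step that the limit leaves unreadable from compound 1 to compound 3, most likely reported again only as a limit.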

Compound 3, half-maximal cytotoxic concentration: 37000 nM
Beside the measured number, compound 3's estimate is 1.6-fold (0.21 log units) above it; the range from low to high includes it.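

Among the compounds shown here, compound 3 is the first compound here to give a number rather than a limit in this assay, so this position can yield a readable value. Putting 4-chlorophenyl in place of 3-chlorophenyl gives an at least 1.3-fold lower number from compound 1 to compound 3 (0.13 log units; that floor lies within the scatter). The true size of this step stays unread, and the value of compound 1 remains only a limit: the limit of > 50000 nM in this assay, at which 1 of the 3 values shown sits.

Going by these compounds, it remains open whether the readable value depends on the chlorine itself. A 4-methoxyphenyl or 4-aminophenyl group at the same aromatic carbon could show this.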